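The source may report more compounds than this note shows. Statements on the series, on what has been measured and on what is new or still open speak of the compounds shown alone.

Measured so far:
Compound 1 `CNc1nc(C)c(C(=O)N/N=C/c2ccccc2C(F)(F)F)s1` gives > 100 ug/mL, which is a limit of the assay and not a number.
Compound 2 `CN(C(=O)NC(=O)c1c(F)cccc1F)c1nc(C(F)(F)F)c(C(=O)N/N=C/c2ccc(C(F)(F)F)cc2)s1` gives 30.6 ug/mL.
Compound 3 `CNc1nc(C(F)(F)F)c(C(=O)N/N=C/c2ccccc2C(F)(F)F)s1` gives > 100 ug/mL, again a limit of the assay rather than a number.

All three were tested in a functional assay on HeLa cells (Homo sapiens) for inhibition, read by MTT assay, with a stated time of 72 h; a lower number here means a stronger inhibitor, a higher number a weaker inhibitor. Compound 2 is the only one of the three with a number; the other two sit at the limit of > 100 ug/mL in this assay, at which 2 of the 3 values shown sit. The step from compound 3 to compound 1, (methyl in place of trifluoromethyl on an aromatic carbon), is a step that the two limits leave unreadable from compound 3 to compound 1. How the core of compound 2 differs from the core of compound 3 is not broken down here.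

Compound 4 `Cc1nc(N(C)C(=O)NC(=O)c2c(F)cccc2F)sc1C(=O)N/N=C/c1ccc(C(F)(F)F)cc1` has not been measured in this assay. It differs from compound 2 by methyl in place of trifluoromethyl on an aromatic carbon. This is the same kind of change as that from compound 3 to compound 1, though the surroundings differ: in compound 4 the carbon lies two ring bonds from the ring atom that bears a large group, while in compound 1 it lies two ring bonds from the ring atom that bears a methylamino group (2 heavy atoms). Within the data shown here, since the only measured example of this change, a step that the two limits leave unreadable from compound 3 to compound 1, gives no readable size, compound 4 is expected to stay close to compound 2, an estimated step of a 1.1-fold higher number from compound 2 to compound 4 (0.06 log units; within the scatter). Compound 4 is therefore estimated at 35 ug/mL in this assay, expected to fall between 12 ug/mL and 100 ug/mL.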

Compound 4, half-maximal inhibitory concentration: 40.6 ug/mL
Compound 4: middle estimate off by 1.2-fold (0.06 log units), on the low side, within the range that was stated.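

In this assay, putting methyl in place of trifluoromethyl on the core of compound 2 gives a 1.3-fold higher number from compound 2 to compound 4 (0.12 log units; within the scatter), so in this one pair the swap produces a difference no larger than repeat measurements would be expected to show. The same swap on the core shared by compound 3 and compound 1 cannot be read, because both compounds give a limit of the assay and not a number: the limit of > 100 ug/mL in this assay, at which 2 of the 4 values shown sit.
Among these compounds, the series therefore offers only one readable example of this change, and a single pair does not show that the result carries over from one core to another, nor that the two cores respond alike.

The compounds shown leave open how other groups on that same aromatic carbon would read on the core of compound 2, such as an ethyl chain, an amine or a carboxylic acid. They also leave open whether a nitrile or a single fluorine there would stay within the scatter.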